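A few compounds are considered here, and "the series" means these few. Any claim that something is new, unique, unknown or untested is made for them only; others in the source may bear on it.

Measured compounds: compound 1 `CCCCNC(=O)Nc1cccc2c1CN(C)CC2c1ccccc1`, 69 mg/kg; compound 2 `CN1Cc2c(NC(=O)OCc3ccccc3)cccc2C(c2ccccc2)C1`, 25 mg/kg; compound 3 `CC(C)NCCC(=O)Nc1cccc2c1CN(C)CC2c1ccccc1`, about 200 mg/kg.

In a functional assay on the whole organism for inhibition of sodium-dependent dopamine transporter (Mus musculus) (on this read-out higher numbers stand for an effect only at larger amounts of compound and lower numbers for an effect already at smaller amounts), compound 3 gives the highest number of the three; compound 1 lies nearest to it and compound 2 furthest. Compound 4 `CN1Cc2c(NC(=O)CN3CCCCC3)cccc2C(c2ccccc2)C1` differs from compound 3 in piperidin-1-yl in place of (isopropylamino)methyl on a saturated chain carbon bound to a carbonyl carbon. For the measured compounds named here, no measured pair alters a group at exactly this place, so only the changes of the whole substituent on the carbonyl carbon bear on it. For compound 4 a modest step downward is expected, a 2.0-fold lower number from compound 3 to compound 4 (0.30 log units; within the scatter), because a 2.9-fold higher number from compound 1 to compound 3 (0.46 log units; beyond the scatter) and an 8.0-fold higher number from compound 2 to compound 3 (0.90 log units; beyond the scatter) both climbed toward compound 3 and a further group at this carbonyl is more likely to fall back toward those neighbours than to rise higher. The estimate for compound 4 is 100 mg/kg, with a range from 35 mg/kg to 300 mg/kg.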

Compound 4, dose for half-maximal effect: about 60 mg/kg
The estimate for compound 4 lay 1.7-fold (0.22 log units) above the measured number, and the stated range covers the measured number.
By their numbers in this assay, from the lowest: compound 2; then compounds 4 and 1 (each within the scatter of the next); then compound 3.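

In this assay, piperidin-1-yl in place of (isopropylamino)methyl, with 0 hydrogen-bond donors instead of 1, gives a 3.3-fold lower number from compound 3 to compound 4 (0.52 log units; beyond the scatter) and shows that this place responds to the change. Against benzyloxy on the carbonyl carbon there remains a 2.4-fold higher number from compound 2 to compound 4 (0.38 log units; beyond the scatter) and against butylamino there is a 1.2-fold lower number from compound 1 to compound 4 (0.06 log units; within the scatter), so a nitrogen on this chain does not by itself give the number of compound 3. No available evidence accounts for these steps.

From the compounds shown here alone, whether the step follows the ring, the hydrogen-bond donor or the shorter chain stays open. Morpholine, dimethylamino or a longer chain carrying piperidin-1-yl could separate these.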